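The source may hold more compounds than are shown below. What is called first, only, known or untested is meant among the compounds shown, and "the series" means these compounds.

Compound 3 `CCC(C(=O)N1CCN(c2cccc(C)c2)CC1)N1C(=O)CCC1=O` is one of the two stronger compounds among the three measured. In a functional assay on the whole organism (strain Swiss) with Mus musculus as the target, in the maximal electroshock model, with a stated time of 1 h, at a dose of 300 mg/kg by the intraperitoneal route (on this read-out higher numbers stand for a stronger effect at the one dose given and lower numbers for a weaker effect), compound 3 gives 75%. Compound 2 `CCC(C(=O)N1CCN(c2cccc(F)c2)CC1)N1C(=O)CCC1=O` gives 75% in this assay, and the two sit together at the top: no change at the digits printed from compound 2 to compound 3 (within the scatter). Compound 1 `CCC(C(=O)N1CCN(c2cccc(OC)c2)CC1)N1C(=O)CCC1=O` gives 0%, far below both: a number 75 percentage points higher from compound 1 to compound 2 (beyond the scatter) and a number 75 percentage points higher from compound 1 to compound 3 (beyond the scatter).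

Compound 4 `CCC(C(=O)N1CCN(c2cccc(Cl)c2)CC1)N1C(=O)CCC1=O` differs from compound 3 in one place: chloro in place of methyl on an aromatic carbon. Within the data shown here, the step that bears most directly on this is the one from compound 2 to compound 3, where fluoro gave way to methyl at the same place and the read-out did not move beyond the scatter. A swap between a halogen and methyl at that place therefore appears to leave the effect where it is, while only the methoxy group of compound 1 stands apart. Because no change at the digits printed from compound 2 to compound 3 (within the scatter), the step of no change at the digits printed from compound 3 to compound 4 (within the scatter) is expected to stay within the scatter. Compound 4 is estimated to give 75% in this assay, expected between 50% and 100%.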

Compound 4, a percentage reported as activity, at one dose (the size of the read-out at that dose, not a potency): 100%
Beside the measured number, compound 4's estimate is 25 percentage points below it; low and high end bracket the measured number.
By their numbers in this assay, from the lowest: compound 1; then compounds 2 and 3 (each within the scatter of the next); then compound 4.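

In this assay, the two halogens at this place do not behave alike: going to chloro from methyl gives a number 25 percentage points higher from compound 3 to compound 4 (beyond the scatter), and going to chloro from fluoro gives a number 25 percentage points higher from compound 2 to compound 4 (beyond the scatter), so the level reading of fluoro and methyl does not extend to every small group there. Compared with methoxy, chloro gives a number 100 percentage points higher from compound 1 to compound 4 (beyond the scatter), which makes compound 4 the strongest of the four at this one dose. Nothing measured here explains why chloro differs from the other groups at this place.

As far as these compounds go, how bromo, trifluoromethyl or an amine would read at this place remains open. So does whether compound 4 would stay ahead of compound 2 and compound 3 at lower doses, since a single dose does not give a potency.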